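Chloro position on the urea phenyl of the benzothiazole series

The source may hold more compounds than are shown below. What is called first, only, known or untested is meant among the compounds shown, and "the series" means these compounds.

Compound 1 `Cc1cc(NC(=O)Nc2ccccc2)ccc1OCc1nc2ccccc2s1` gives 2070 nM in an assay on isolated protein for inhibition of Polyunsaturated fatty acid 5-lipoxygenase (Homo sapiens), read by HPLC, with a stated time of 10 min; on this read-out higher numbers stand for weaker inhibition and lower numbers for stronger inhibition. Compound 2 `Cc1cc(NC(=O)Nc2ccccc2Cl)ccc1OCc1nc2ccccc2s1` gives 680 nM in this assay; the step of a 3.0-fold lower number from compound 1 to compound 2 (0.48 log units; beyond the scatter) is a modest gain and stands beyond the scatter. For the measured compounds named here, compound 2 thus holds the lowest number of the two measured, with compound 1 the only comparison. Compound 3 `Cc1cc(NC(=O)Nc2cccc(Cl)c2)ccc1OCc1nc2ccccc2s1` differs from compound 2 by 3-chlorophenyl in place of 2-chlorophenyl on an amide-type nitrogen, so the chloro atom is kept but moved on the ring. Going by the values given here, the only measured step that bears on this, from compound 1 to compound 2, concerns adding chloro, not moving it, so it gives no direct guide on the new position. The expectation is therefore a small loss within the scatter or no change beyond it, a 1.5-fold higher number from compound 2 to compound 3 (0.17 log units; within the scatter), with compound 3 estimated at 1000 nM in this assay, in a range from 400 nM to 3000 nM.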

Compound 3, half-maximal inhibitory concentration: 2090 nM
Estimate against measurement, compound 3: 2.1-fold (0.32 log units) below, within the range that was stated.
By their numbers in this assay, from the lowest: compound 2; then compounds 1 and 3 (each within the scatter of the next).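

Moving the chloro from 2-chlorophenyl to 3-chlorophenyl on the amide-type nitrogen gives up the earlier gain in this assay (a 3.1-fold higher number from compound 2 to compound 3 (0.49 log units; beyond the scatter)). Chloro in place of hydrogen at this new position reads differently from the first chloro step (a 1.0-fold higher number from compound 1 to compound 3 (0.00 log units; within the scatter)), so among these compounds the gain from chloro goes with 2-chlorophenyl and not with chloro on this ring as such. No independent data bear on why the position matters.

Open, as far as these compounds go, is whether the gain needs chloro itself: a methoxy or a fluoro in place of the chloro of 2-chlorophenyl would test that. Also open, from the compounds shown here alone, is whether 2-chlorophenyl keeps its edge over 3-chlorophenyl when the methyl on the shared core gives way to hydrogen.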